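The compounds below may be only part of what the source reports. "The series", "measured", "known", "first", "only" and "open" are said of these compounds alone.

In a functional assay on KB cells (Homo sapiens) for antiproliferative activity, read by sulforhodamine B assay, with a stated time of 3 days (a lower number here means that less compound is needed, a higher number that more compound is needed for the effect), compound 1 `CCC1=C(O)c2c(oc(-c3ccc(OC)cc3)cc2=O)C(CC)(CC)C1=O` gives 17.7 uM. Compound 2 `CCC1=C(O)c2c(oc(-c3ccc(SC)cc3)cc2=O)C(CC)(CC)C1=O` differs only in having methylsulfanyl in place of methoxy on an aromatic carbon, and it reads > 52.1 uM. That reading is a limit of the assay and not a number. It leaves compound 2 with no exact place on the scale, only (the limit of > 52.1 uM in this assay, at which 1 of the 2 values shown sits).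

The next compound, compound 3 `CCC1=C(O)c2c(oc(-c3ccc(CBr)cc3)cc2=O)C(CC)(CC)C1=O`, has bromomethyl in place of methylsulfanyl on an aromatic carbon, at the same site: bromomethyl in place of methylsulfanyl on an aromatic carbon. Among the compounds with values here, the single measured step at this site is an at least 2.9-fold higher number from compound 1 to compound 2 (0.46 log units; beyond the scatter), which lies beyond the scatter. That one step shows that a small swap here can move the number in this assay, though it says nothing directly about bromomethyl. With methylsulfanyl gone, some return towards the range of compound 1 at 17.7 uM seems the likelier outcome. Compound 3 may also end up reported only as a limit. The expected change is an at least 2.0-fold lower number from compound 2 to compound 3 (0.31 log units; beyond the scatter), towards a lower number. For compound 3 the estimated value is 25 uM, with an expected range from 8 uM to 70 uM.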

Compound 3, concentration for half-maximal effect: > 46.5 uM
Compound 3: no number, only a limit; the forecaster's own chance of this, stated with the estimate: 30%; at least 1.8-fold (0.26 log units) between middle value and limit.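

In this assay compound 3 reads > 46.5 uM, which is a limit of the assay and not a number. Measured against the methoxy group, bromomethyl gives an at least 2.6-fold higher number from compound 1 to compound 3 (0.41 log units; beyond the scatter), so a second replacement at this site now moves the number in the same direction as methylsulfanyl did, where the earlier step was an at least 2.9-fold higher number from compound 1 to compound 2 (0.46 log units; beyond the scatter). Compound 1 thus remains the only one of the three with an exact value, while the step between compound 2 and compound 3 cannot be read, and neither replacement can be ranked against the other.

As far as these compounds go, what stays open is how far compound 2 and compound 3 really lie from compound 1, and whether methoxy is special here or whether these two replacements simply share a poor outcome. An amine, a carboxylic acid or a longer chain such as ethoxy on the same aromatic carbon would test whether the trend seen in these three compounds extends to other groups, and any such group giving an exact value would give this site a second real number on the scale.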